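A few compounds are considered here, and "the series" means these few. Any claim that something is new, unique, unknown or untested is made for them only; others in the source may bear on it.

In a toxicity assay on MDCK cells (Canis lupus familiaris) for cytotoxicity, read by crystal violet staining, with a stated time of 48 h (a higher number here means that more compound is tolerated, a lower number that less compound is tolerated), compound 3, with the structure `Cc1ccc2[nH]c(=O)c(CN(Cc3ccc(C(N)=O)cc3)Cc3ccc(C(C)(C)C)cc3)cc2c1`, gives only a limit of the assay, > 5000 nM (the limit of > 5000 nM in this assay, at which 1 of the 3 values shown sits). Compound 1, `Cc1ccc2cc(CN(Cc3ccc(F)cc3)Cc3ccc(C(C)C)cc3)c(=O)[nH]c2c1`, likewise gives only a limit in this assay, > 33000 nM (the limit of > 33000 nM in this assay, at which 1 of the 3 values shown sits). For compound 2, `Cc1cccc2cc(CN(Cc3ccc(F)cc3)Cc3ccc(C(C)(C)C)cc3)c(=O)[nH]c12`, this assay records "not determined" (no result reported), so no result was reported. Compound 4, `Cc1ccc2[nH]c(=O)c(CN(Cc3ccc(C(C)(C)C)cc3)Cc3ccc(N(C)C)c(Cl)c3)cc2c1`, differs from compound 3 in one place: 3-chloro-4-(dimethylamino)phenyl in place of 4-carbamoylphenyl on a saturated chain carbon bound to an amine nitrogen. Within the data shown here, no step between two measured compounds is available here, so any expectation rests on the limits alone. The step that the limit leaves unreadable from compound 3 to compound 4 is expected to stay within the scatter of this assay, with no clear direction. Compound 4 is thus estimated at 20000 nM, in a range from 5000 nM to 60000 nM.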

Compound 4, half-maximal cytotoxic concentration: > 10000 nM
Compound 4: only a limit was reported (the forecaster's own chance of this, stated with the estimate: 60%); the middle value does not contradict the limit.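

Compound 3 and compound 4 both give only limits in this assay, so the step between them cannot be read. From the compounds shown here alone, whether 3-chloro-4-(dimethylamino)phenyl in place of 4-carbamoylphenyl changes the tolerated concentration at all stays open.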